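Trifluoromethyl in place of methoxy: expectation for compound 3

A few compounds are considered here, and "the series" means these few. Any claim that something is new, unique, unknown or untested is made for them only; others in the source may bear on it.

Going by the values given here, the series so far holds two compounds measured in a functional assay on NCI-H460 cells (Homo sapiens) for cytotoxicity, read by MTT assay, with a stated time of 68 h; on this read-out higher numbers stand for weaker inhibition and lower numbers for stronger inhibition. Compound 1 (`Nc1cccc(-c2cccc(NC(=O)C(Cl)Cl)c2)c1`) reads > 50000 nM, which is a limit of the assay and not a number. Among the compounds with values here, compound 2 (`COc1cccc(-c2cccc(NC(=O)C(Cl)Cl)c2)c1`) gives 33800 nM, the only actual number available, so it has no numerical neighbour against which to be ranked.

The next compound is compound 3 (`O=C(Nc1cccc(-c2cccc(C(F)(F)F)c2)c1)C(Cl)Cl`), with trifluoromethyl in place of methoxy on an aromatic carbon. Within the data shown here, the only measured change at this position is an at least 1.4-fold lower number from compound 1 to compound 2 (0.17 log units; that floor lies within the scatter), and its floor stays within the scatter. That step concerns a different pair of groups and gives only weak guidance, with no measured case of trifluoromethyl in the series. No clear direction can therefore be drawn from it, and no shift beyond the scatter is expected in this assay. The expected step, a 1.4-fold lower number from compound 2 to compound 3 (0.13 log units; within the scatter), is correspondingly small. For compound 3 the estimated value is 25000 nM, with an expected range of 10000 nM to 50000 nM.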

Compound 3, half-maximal inhibitory concentration: 30200 nM
Compound 3: the middle estimate sits 1.2-fold (0.08 log units) below what was measured; low and high end bracket the measured number.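

In this assay, trifluoromethyl in place of methoxy gives a 1.1-fold lower number from compound 2 to compound 3 (0.05 log units; within the scatter), so this position now holds two real numbers, and the exchange of a group with one hydrogen-bond acceptor for a larger one with none brings no shift beyond the scatter. Trifluoromethyl in place of amino gives an at least 1.6-fold lower number from compound 1 to compound 3 (0.21 log units; that floor lies within the scatter), so the floor of this comparison also stays within the scatter and does not separate the amino compound from the other two. Compound 1 remains a limit of the assay and not a number, which leaves this step with a floor and no measured size: the limit of > 50000 nM in this assay, at which 1 of the 3 values shown sits.

The compounds shown leave open whether any group at this position can move the number beyond the scatter, for example a carboxylic acid, a nitrile or a longer chain such as butoxy. They also leave open whether the amide part of the shared core, which is the same in compound 1, compound 2 and compound 3, has more influence on this read-out than the aromatic substituent.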